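Alkoxy and thioether variation on the shared core

The source may hold more compounds than are shown below. What is called first, only, known or untested is meant among the compounds shown, and "the series" means these compounds.

Compound 1, `CO[C@]1(C(=O)O)C=C[C@@H](NC(C)=O)[C@H]([C@H](O)[C@H](O)CO)O1`, gives only a limit in an assay on HEK293 cells for inhibition of sialidase-3 (Homo sapiens), read by fluorescence, with a stated time of 1 h (a lower number here means a stronger inhibitor, a higher number a weaker inhibitor), namely > 1000000 nM. Compound 2, `CCS[C@@]1(C(=O)O)C=C[C@@H](NC(C)=O)[C@H]([C@H](O)[C@H](O)CO)O1`, likewise gives only a limit in this assay, > 1000000 nM. Compound 2 therefore stands at the limit of > 1000000 nM in this assay, at which 2 of the 2 values shown sit, with no number to rank it against compound 1. Compound 3, `CC(=O)N[C@@H]1C=C[C@@](OC(C)C)(C(=O)O)O[C@H]1[C@H](O)[C@H](O)CO`, carries isopropoxy in place of ethylsulfanyl on a saturated ring carbon, isopropoxy in place of ethylsulfanyl on a saturated ring carbon. For the measured compounds named here, no measured step exists for this change, and neither neighbour gives a number, so no movement beyond the scatter is expected; the step of a number no higher from compound 2 to compound 3 (the limit leaves the size open) is an estimate. Compound 3 is expected at 1000000 nM, within 300000 nM to 3000000 nM, most probably reported again as a limit.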

Compound 3, half-maximal inhibitory concentration: > 1000000 nM
Compound 3: only a limit was reported; the forecaster's own chance of this, stated with the estimate: 85%; the middle value lies on the limit itself.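

Compound 2 and compound 3 both give only limits, so no step can be read between them: the limit of > 1000000 nM in this assay, at which 3 of the 3 values shown sit. The compounds shown leave open whether any group at this place on the shared core gives a measurable value in this assay.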